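A few compounds are considered here, and "the series" means these few. Any claim that something is new, unique, unknown or untested is made for them only; others in the source may bear on it.

Compound 2 `CN1[C@@H]2c3[nH]c4ccccc4c3C[C@H]1[C@H](C#N)N1[C@@H](CNC(=O)c3ccc4ccccc4c3)c3[nH]c4ccccc4c3C[C@@H]21` stands at the high end of the two numbers measured: in a functional assay on BGC-823 cells (Homo sapiens) for cytotoxicity, read by MTT assay, with a stated time of 72 h (on this read-out higher numbers stand for weaker inhibition and lower numbers for stronger inhibition), compound 2 gives 1110 nM. Going by the values given here, the only comparison is compound 1 `CN1[C@@H]2c3[nH]c4ccccc4c3C[C@H]1[C@H](C#N)N1[C@@H](CNC(=O)c3ccc(F)cc3)c3[nH]c4ccccc4c3C[C@@H]21`, which in this assay gives 310 nM. The step of a 3.6-fold higher number from compound 1 to compound 2 (0.55 log units; beyond the scatter) shows that putting naphthalen-2-yl in place of 4-fluorophenyl on the carbonyl carbon of the amide weakened the inhibition. Compound 3 `CN1[C@@H]2c3[nH]c4ccccc4c3C[C@H]1[C@H](C#N)N1[C@@H](CNC(=O)/C=C/c3cccc(C(F)(F)F)c3)c3[nH]c4ccccc4c3C[C@@H]21` alters this same group once more: 2-(3-(trifluoromethyl)phenyl)ethenyl in place of naphthalen-2-yl on a carbonyl carbon. Among the compounds with values here, the single step that bears on it, a 3.6-fold higher number from compound 1 to compound 2 (0.55 log units; beyond the scatter), came from a different replacement and so gives only a loose guide; the entering group, like naphthalen-2-yl, leaves the 4-fluorophenyl of compound 1 absent, so the outcome is expected to stay near compound 2, without a change beyond the scatter. Compound 3 is therefore estimated to give 750 nM in this assay, within a likely range from 250 nM to 2200 nM. That estimate amounts to an expected step of a 1.5-fold lower number from compound 2 to compound 3 (0.17 log units; within the scatter).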

Compound 3, half-maximal inhibitory concentration: 910 nM
Estimate against measurement, compound 3: 1.2-fold (0.08 log units) below; the range from low to high includes it.
By their numbers in this assay, from the lowest: compound 1; then compounds 3 and 2 (each within the scatter of the next).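

In this assay, placing 2-(3-(trifluoromethyl)phenyl)ethenyl instead of naphthalen-2-yl on the carbonyl carbon gives a 1.2-fold lower number from compound 2 to compound 3 (0.09 log units; within the scatter), so these two groups cannot be told apart here, although one holds two aromatic rings and the other holds one aromatic ring plus a double bond outside it. Set against 4-fluorophenyl, the same group gives a 2.9-fold higher number from compound 1 to compound 3 (0.47 log units; beyond the scatter), so two differently built groups now both give weaker inhibition than 4-fluorophenyl, and the loss seen earlier is not peculiar to naphthalen-2-yl. Nothing measured here accounts for these numbers.

Still open, from the compounds shown here alone, is whether the result for compound 1 depends on its fluorine, which a plain phenyl on the same carbonyl carbon would test. Equally open, going by these compounds, is how a pyridine ring, or a phenyl carrying an amine or a carboxylic acid, would behave there.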